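Back from a benzyl amide to a phenyl amide

This account rests on a few compounds, and the source may have more. Where it says the series, first, only, none or still open, it means among the compounds named here.

Compound 1 `COc1cccc(NC(=O)/C=C/c2coc3cc(OC)ccc3c2=O)c1`: in a functional assay on HeLa cells (Homo sapiens) for inhibition, read by MTT assay, with a stated time of 48 h (a higher number here means a weaker inhibitor, a lower number a stronger inhibitor), compound 1 gives 19200 nM.
Compound 2 `COc1ccc2c(=O)c(/C=C/C(=O)NCc3ccc(F)cc3)coc2c1`: in this assay compound 2 gives > 100000 nM, a limit of the assay.
Compound 3 `COc1ccc(CNC(=O)/C=C/c2coc3cc(OC)ccc3c2=O)cc1`: in this assay compound 3 gives > 100000 nM, also a limit of the assay.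

Compound 3 thus stands at the limit of > 100000 nM in this assay, at which 2 of the 3 values shown sit, with no number of its own. Compound 4 `COc1ccc2c(=O)c(/C=C/C(=O)Nc3ccccc3OC)coc2c1` differs from it by 2-methoxyphenyl in place of 4-methoxybenzyl on an amide-type nitrogen. The measured steps that bear on this change run the other way: an at least 5.2-fold higher number from compound 1 to compound 3 (0.71 log units; beyond the scatter) and an at least 5.2-fold higher number from compound 1 to compound 2 (0.71 log units; beyond the scatter). Both moved a phenyl amide of compound 1 up to the limit when a benzyl group entered, so the return to a phenyl amide in compound 4 is expected to lower the number, by an at least 4.0-fold lower number from compound 3 to compound 4 (0.60 log units; beyond the scatter). Compound 4 is therefore estimated at 25000 nM, within a range from 6000 nM to 100000 nM.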

Compound 4, half-maximal inhibitory concentration: > 100000 nM
Compound 4 gave a limit, no number; the forecaster's own chance of this, stated with the estimate: 30%; middle value at least 4.0-fold (0.60 log units) away from the limit.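

Putting 2-methoxyphenyl in place of 3-methoxyphenyl on the amide-type nitrogen gives an at least 5.2-fold higher number from compound 1 to compound 4 (0.71 log units; beyond the scatter), so a phenyl amide as such does not secure a measurable number here, something the two benzyl amides could not show. The steps from compound 2 and from compound 3 to compound 4 cannot be read, with limits at both ends. In this assay the series now crowds at one ceiling: the limit of > 100000 nM in this assay, at which 3 of the 4 values shown sit.

On these data alone, whether an unsubstituted phenyl or a phenyl carrying an amine on this nitrogen would give a number remains open. So does how much weaker compound 2, compound 3 and compound 4 really are.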